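Removing a Chloro Group in a Weak Antiproliferative Series

The compounds below may be only part of what the source reports. "The series", "measured", "known", "first", "only" and "open" are said of these compounds alone.

The measured compounds:
compound 1, `O=C1COc2ccc(-c3cccc(NS(=O)(=O)c4ccc(F)cc4)c3)cc2N1c1ccc(Cl)cc1`, 31600 nM
compound 2, `O=C1COc2ccc(-c3cccc(NS(=O)(=O)c4ccc(F)cc4)c3)cc2N1c1ccccc1`, > 40000 nM
compound 3, `O=C1COc2ccc(-c3cnc4ccccc4c3)cc2N1c1ccc(Cl)cc1`, > 40000 nM

All three were tested in a functional assay on A549 cells (Homo sapiens) for antiproliferative activity, read by MTT assay, with a stated time of 72 h; a lower number here means a stronger inhibitor, a higher number a weaker inhibitor. Compound 1 gives 31600 nM, a weak effect. For compound 2 the result is only a limit of the assay, > 40000 nM, not a number. For compound 3 the result is likewise a limit, > 40000 nM. Among the compounds with values here, the only single change between measured compounds is hydrogen in place of chloro on an aromatic carbon, and it made an at least 1.2-fold higher number from compound 1 to compound 2 (0.10 log units; that floor lies within the scatter). This step can be read only as a floor, because the limit of > 40000 nM in this assay, at which 2 of the 3 values shown sit, caps what the assay can report. The difference between the core of compound 1 and the core of compound 3 is not broken down here.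

Compound 4, `O=C1COc2ccc(-c3cnc4ccccc4c3)cc2N1c1ccccc1`, has not yet been measured. Within the data shown here, it differs from compound 3 by hydrogen in place of chloro on an aromatic carbon, the same kind of change as the one from compound 1 to compound 2, and the surroundings of the place are described in the same words. Compound 3 already sits at a limit, > 40000 nM. The step of an at least 1.2-fold higher number from compound 1 to compound 2 (0.10 log units; that floor lies within the scatter) did not lower the number. On these grounds compound 4 is expected to show a step that the limit leaves unreadable from compound 3 to compound 4. The estimate for compound 4 is 60000 nM, expected between 30000 nM and 150000 nM, most likely again reported only as a limit.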

Compound 4, half-maximal inhibitory concentration: > 40000 nM
Compound 4 was reported as a limit; the forecaster's own chance of this, stated with the estimate: 85%; the middle value is on the limit's open side.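

In this assay compound 4 gives > 40000 nM, a limit and not a number. No step can be read from compound 3 to compound 4, because both results stop at the same limit: the limit of > 40000 nM in this assay, at which 3 of the 4 values shown sit. The compounds shown leave open how strongly compound 2, compound 3 and compound 4 act on these cells, and whether replacing chloro with hydrogen changes anything on the core of compound 3.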